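Methoxy added to compound 2: working notes

The source may hold more compounds than are shown below. What is called first, only, known or untested is meant among the compounds shown, and "the series" means these compounds.

Measured in a functional assay; a lower number here means a stronger inhibitor, a higher number a weaker inhibitor:
- compound 1 (`COc1ccc(C2CC(=O)c3ccc(OCC=C(C)C)cc3O2)c(OC)c1`): 8180 nM
- compound 2 (`COc1ccc(C2CC(=O)c3c(O)cc(OCC=C(C)C)cc3O2)cc1`): 5080 nM

Compound 2 at 5080 nM lies within the scatter of compound 1 at 8180 nM and so cannot be ranked against it. Compound 3 (`COc1ccc(C2CC(=O)c3c(O)cc(OCC=C(C)C)cc3O2)c(OC)c1`) has methoxy in place of hydrogen on an aromatic carbon of compound 2 (methoxy in place of hydrogen on an aromatic carbon). Among the compounds with values here, no measured step yet shows what this change does. The expected 1.1-fold higher number from compound 2 to compound 3 (0.03 log units; within the scatter) in this assay stays within the scatter, with no direction favoured. Compound 3 is estimated at 5500 nM with an expected range from 2500 nM to 12000 nM on this reading.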

Compound 3, half-maximal inhibitory concentration: 2320 nM
Estimate against measurement, compound 3: 2.4-fold (0.37 log units) above, outside the stated range (below it).
By their numbers in this assay, from the lowest: compound 3; then compounds 2 and 1 (each within the scatter of the next).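

In this assay, methoxy in place of hydrogen on an aromatic carbon, ortho to a large group, gives a step beyond the scatter (a 2.2-fold lower number from compound 2 to compound 3 (0.34 log units; beyond the scatter)), so this position responds to the change. A hydroxy group added to the core of compound 1, the other single change leading to compound 3, also gives a step beyond the scatter (a 3.5-fold lower number from compound 1 to compound 3 (0.55 log units; beyond the scatter)). Nothing on hand explains either step.

On these data alone, whether the lower number is specific to methoxy remains open, as ethoxy or chlorine on this carbon would test. Also open, as far as these compounds go, is whether the hydroxy step holds without this methoxy.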